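The compounds below may be only part of what the source reports. "The series", "measured", "known", "first", "only" and "open" are said of these compounds alone.

Working notes on the thiophene-coumarin series. In an in vitro assay on BTI-TN-5B1-4 cells for inhibition of Amine oxidase [flavin-containing] B (Homo sapiens), read by fluorescence (on this read-out higher numbers stand for weaker inhibition and lower numbers for stronger inhibition), compound 1 `O=c1oc2ccccc2cc1-c1ccsc1` gives 13300 nM. In this assay compound 2 `COc1ccc2cc(-c3cccs3)c(=O)oc2c1` gives 263 nM. In this assay compound 3 `COc1ccc2oc(=O)c(-c3cccs3)cc2c1` gives 634 nM, the second highest of the three numbers; compound 2 stands nearest, lower by more than the scatter, and compound 1 furthest, higher by more than the scatter. Compound 4 `COc1ccc2oc(=O)c(-c3ccsc3)cc2c1` is not yet measured in this assay. It differs from compound 3 by thiophen-3-yl in place of thiophen-2-yl on an aromatic carbon. For the measured compounds named here, no measured pair isolates this swap; compound 1, which also carries thiophen-3-yl, is the weakest of the measured compounds, but it differs from compound 3 in other respects too. A moderate rise in the number, beyond the scatter, is expected for the step of a 3.2-fold higher number from compound 3 to compound 4 (0.50 log units; beyond the scatter). Compound 4 is estimated at 2000 nM, within 500 nM to 8000 nM.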

Compound 4, half-maximal inhibitory concentration: 234 nM
Compound 4: the middle estimate sits 8.5-fold (0.93 log units) above what was measured; the measured number lies below the stated range.
By their numbers in this assay, from the lowest: compounds 4 and 2 (each within the scatter of the next); then compound 3; then compound 1.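

On the aromatic carbon two atoms from the ring oxygen, thiophen-3-yl in place of thiophen-2-yl gives a 2.7-fold lower number from compound 3 to compound 4 (0.43 log units; beyond the scatter) with the atoms unchanged, so the attachment point of the thiophene alone shifts the read-out towards stronger inhibition. With thiophen-3-yl held, methoxy in place of hydrogen gives a 57-fold lower number from compound 1 to compound 4 (1.75 log units; beyond the scatter) and so ties the weak reading of compound 1 to the missing methoxy, not to thiophen-3-yl. Nothing at hand bears on the reason for either step.

Going by these compounds, whether thiophen-3-yl also gives the lower number with the methoxy placed as in compound 2 stays open. So does how an amine or a carboxylic acid would read in place of the methoxy.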